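Aniline swap on the shared core: cytotoxicity notes

The source may report more compounds than this note shows. Statements on the series, on what has been measured and on what is new or still open speak of the compounds shown alone.

Compound 1 `Fc1cccc(Nc2c(-c3ccccn3)nc3ccccn23)c1` gives > 50000 nM in an ADME assay on THP-1 cells (Homo sapiens) for cytotoxicity (on this read-out lower numbers stand for higher toxicity in this test and higher numbers for lower toxicity in this test), which is a limit of the test rather than a number.
Compound 2 `COc1ccn2c(Nc3ccccc3F)c(-c3ccccn3)nc2c1` gives 5750 nM in this assay.

Within the data shown here, compound 2 carries the only numeric reading in this set; the other reading sits at the limit of > 50000 nM in this assay, at which 1 of the 2 values shown sits. Compound 3 `COc1ccn2c(Nc3cc(Cl)ccc3Cl)c(-c3ccccn3)nc2c1` is not yet measured. It differs from compound 2 by 2,5-dichlorophenyl in place of 2-fluorophenyl on a nitrogen on an aromatic ring. Among the measured compounds shown here, no measured pair isolates this change, so the size of the step is not anchored by data. Compound 3 is expected to come out somewhat more toxic than compound 2, by a 1.6-fold lower number from compound 2 to compound 3 (0.22 log units; within the scatter), a step close to the usual scatter. Compound 3 is estimated at 3500 nM, within a range of 1500 nM to 9000 nM.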

Compound 3, half-maximal cytotoxic concentration: 8930 nM
For compound 3 the middle estimate is 2.6-fold (0.41 log units) below the measured one; the measured number falls inside the stated range.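

Among these compounds, this is the first pair that isolates a single change, and at this position on the nitrogen it gives in this assay a 1.6-fold higher number from compound 2 to compound 3 (0.19 log units; within the scatter). On this shared core, 2,5-dichlorophenyl and 2-fluorophenyl therefore cannot be told apart in this read-out. No measurement shown bears on the cause of this step.

The compounds shown leave open how an aryl group carrying an amine or a carboxylic acid would read at this nitrogen. As far as these compounds go, a longer alkyl chain in place of the aryl group also remains open.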